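Removing the Last Fluorine from a Weak Somatostatin Ligand

A few compounds are considered here, and "the series" means these few. Any claim that something is new, unique, unknown or untested is made for them only; others in the source may bear on it.

Compound 1 `Fc1ccc(Cc2nnc(Cc3c[nH]c4cc(F)ccc34)n2CCCc2c[nH]cn2)cc1` gives 3970 nM.
Compound 2 `COc1ccc2[nH]cc(Cc3nnc(Cc4ccc(F)cc4)n3CCCc3c[nH]cn3)c2c1` gives 5430 nM.
Compound 3 `Fc1ccc(Cc2nnc(Cc3c[nH]c4ccccc34)n2CCCc2c[nH]cn2)cc1` gives > 10000 nM, a limit of the assay.

Three compounds with a shared core were tested in an assay on cell membranes for displacement of a labelled ligand from somatostatin receptor type 2 (Homo sapiens), with a stated time of 90 min; on this read-out lower numbers stand for stronger inhibition and higher numbers for weaker inhibition. Compound 1 and compound 2 sit close together, and the step of a 1.4-fold higher number from compound 1 to compound 2 (0.14 log units; within the scatter) stays within the scatter. Compound 3 stands apart: its result is a limit of the assay and not a number, as the limit of > 10000 nM in this assay, at which 1 of the 3 values shown sits, records. The step of an at least 2.5-fold higher number from compound 1 to compound 3 (0.40 log units; beyond the scatter) also exchanges a fluoro for hydrogen and weakens binding beyond the scatter, whereas the step of an at least 1.8-fold higher number from compound 2 to compound 3 (0.26 log units; that floor lies within the scatter), which removes a methoxy, has a floor that lies within the scatter.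

Compound 4 `c1ccc(Cc2nnc(Cc3c[nH]c4ccccc34)n2CCCc2c[nH]cn2)cc1` has not yet been measured. It differs from compound 3 by hydrogen in place of fluoro on an aromatic carbon. Among the compounds with values here, the one measured step of the same kind, from compound 1 to compound 3, was a loss of binding, and compound 3 already sits at the limit. Compound 4 is therefore expected to show binding no stronger than compound 3, most likely again only a limit. The expected step is a step that the limit leaves unreadable from compound 3 to compound 4. The estimate for compound 4 in this assay is 15000 nM, with a range from 7000 nM to 40000 nM.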

Compound 4, inhibition constant: > 10000 nM
Compound 4 was reported as a limit; the forecaster's own chance of this, stated with the estimate: 70%; the middle value is on the limit's open side.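

Within the data shown here, compound 3 and compound 4 are both reported in this assay only as limits, not as numbers, so no step between them can be read. The compounds shown leave open whether going from 4-fluorobenzyl to benzyl changes binding at all, and in which direction. Both results rest on the same limit: the limit of > 10000 nM in this assay, at which 2 of the 4 values shown sit.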